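This account rests on a few compounds, and the source may have more. Where it says the series, first, only, none or still open, it means among the compounds named here.

Two compounds built on a shared core carry a urea whose far nitrogen bears an aryl group, and they differ only in that aryl group. Compound 1 `COc1cc(Nc2ncnc3c(NC(=O)Nc4cc(Cl)cc(Cl)c4)cccc23)cc(OC)c1` has a 3,5-dichlorophenyl there, and in a functional assay on RT-112 cells (Homo sapiens) for antiproliferative activity, read by MTT assay, with a stated time of 72 h (on this read-out lower numbers stand for stronger inhibition of growth and higher numbers for weaker inhibition of growth), compound 1 gives 30.2 nM. Compound 2 `COc1cc(Nc2ncnc3c(NC(=O)Nc4cccc(Cc5ccccc5)c4)cccc23)cc(OC)c1` has instead a phenyl carrying a benzyl group, and in this assay compound 2 gives 1740 nM. Compound 1 therefore holds the lower of the two numbers, and its gap to compound 2 lies beyond the usual scatter.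

Compound 3 `COc1cc(Nc2ncnc3c(NC(=O)Nc4ccc(Cl)cc4Cl)cccc23)cc(OC)c1` has not yet been measured. It differs from compound 1 in one place: 2,4-dichlorophenyl in place of 3,5-dichlorophenyl on an amide-type nitrogen. The two have the same atoms, joined differently. Going by the values given here, no measured pair shows a rearrangement of this kind, so the expectation rests on compound 1 and its 30.2 nM alone. A moderate step toward weaker inhibition of growth, somewhat beyond the scatter, is expected, written as a 5.0-fold higher number from compound 1 to compound 3 (0.70 log units; beyond the scatter). For compound 3 the estimate in this assay is 150 nM, with a range from 40 nM to 600 nM.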

Compound 3, concentration for 50% growth inhibition: 3060 nM
The estimate for compound 3 lay 20-fold (1.31 log units) below the measured number; the whole stated range lies below it.
By their numbers in this assay, from the lowest: compound 1; then compounds 2 and 3 (each within the scatter of the next).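

Exchanging 3,5-dichlorophenyl for 2,4-dichlorophenyl on an amide-type nitrogen leaves the atoms unchanged yet gives a 100-fold higher number from compound 1 to compound 3 (2.01 log units; beyond the scatter) in this assay, so at this position the arrangement of the two chlorines alone is enough to separate the compounds widely. The earlier pair could not show this, as its two aryl groups also differed in their atoms; now compound 3 at 3060 nM and compound 2 at 1740 nM stand within the scatter of each other, and of the three aryl groups shown, only the 3,5-dichlorophenyl of compound 1 goes with a number clearly lower than the others. Nothing measured here accounts for the size of this step.

The compounds shown leave open whether chlorine itself is needed, since none of them carries a trifluoromethyl, a methoxy, a nitrile or an amine on this aryl ring in its place. They also leave open whether the same rearrangement of two chlorines would bring a step of similar size on a different core or in other cells.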